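Notes on a methyl variant of compound 2

The compounds below may be only part of what the source reports. "The series", "measured", "known", "first", "only" and "open" are said of these compounds alone.

Compound 2 `CN1Cc2ccc(OCc3ccccc3)cc2[C@@H](O)C1` stands at a limit of the assay in an ADME assay on Vero cells (Chlorocebus sabaeus) for cytotoxicity, read by sulforhodamine B assay, with a stated time of 72 h; on this read-out higher numbers stand for weaker inhibition and lower numbers for stronger inhibition: compound 2 gives > 100000 nM. Compound 1 `COc1ccc2c(c1)[C@@H](O)CN(C)C2` gives a limit as well; in this assay compound 1 gives > 100000 nM. Compound 3 `COc1ccc(COc2ccc3c(c2)[C@@H](O)CN(C)C3)cc1` likewise gives a limit, as in this assay compound 3 gives > 50000 nM. The steps a step that the two limits leave unreadable from compound 1 to compound 2 and a step that the two limits leave unreadable from compound 2 to compound 3 therefore carry no readable size; two of the three values sit at the limit of > 100000 nM in this assay, at which 2 of the 3 values shown sit, and one at the limit of > 50000 nM in this assay, at which 1 of the 3 values shown sits.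

Compound 4 `Cc1cccc(COc2ccc3c(c2)[C@@H](O)CN(C)C3)c1` differs from compound 2 by methyl in place of hydrogen on an aromatic carbon. Within the data shown here, no measured step gives a size for this change, so no step beyond the scatter is expected in this assay. Compound 4 is expected at 150000 nM, most likely between 70000 nM and 400000 nM. The step that the limit leaves unreadable from compound 2 to compound 4 is expected to stay within the scatter, with the value again most likely reported as a limit.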

Compound 4, half-maximal inhibitory concentration: > 50000 nM
Compound 4: only a limit was reported (the forecaster's own chance of this, stated with the estimate: 85%); the middle value lies beyond the limit too.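

In this assay compound 4 gives > 50000 nM, a limit, so the steps to compound 4 from compound 1 and compound 2 cannot be read. Left open is whether the methyl changes cytotoxicity at all.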